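The source may report more compounds than this note shows. Statements on the series, on what has been measured and on what is new or still open speak of the compounds shown alone.

Measured so far in a functional assay on A549 cells (Homo sapiens) for inhibition, read by CCK-8 assay, with a stated time of 72 h, tested at 1 uM; on this read-out higher numbers stand for a stronger effect at the one concentration tested and lower numbers for a weaker effect:

- compound 1, `CN(C)C(=O)c1cc2cnc(Nc3ccc(S(=O)(=O)NCCCCCN=C=S)cc3)nc2n1C1CCCC1`: 56.6%
- compound 2, `CN(C)C(=O)c1cc2cnc(Nc3ccc(S(=O)(=O)NCCCCCCN=C=S)cc3)nc2n1C1CCCC1`: 49.5%
- compound 3, `CN(C)C(=O)c1cc2cnc(Nc3ccc(C(=O)NCCCN=C=S)cc3F)nc2n1C1CCCC1`: 16.7%

Compound 3 gives the lowest of the three numbers; its distance to compound 2 and to compound 1 lies beyond the scatter. The difference between the core of compound 3 and the core of compound 1 is not broken down here.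

Compound 4, `CN(C)C(=O)c1cc2cnc(Nc3ccc(C(=O)NCCCCN=C=S)cc3F)nc2n1C1CCCC1`, is not yet measured. It differs from compound 3 by a group of 4 heavy atoms (2 carbon, 1 nitrogen, 1 sulfur; no ring) in place of a group of 3 heavy atoms (1 carbon, 1 nitrogen, 1 sulfur; no ring), on a saturated chain carbon, three bonds along the chain from an amide-type nitrogen. The same kind of change is seen from compound 1 to compound 2, (a group of 4 heavy atoms (2 carbon, 1 nitrogen, 1 sulfur; no ring) in place of a group of 3 heavy atoms (1 carbon, 1 nitrogen, 1 sulfur; no ring), on a saturated chain carbon, five bonds along the chain from a sulfonamide nitrogen), where the chain is attached five bonds from a sulfonamide nitrogen rather than three bonds from an amide-type nitrogen; that step gave a number 7.1 percentage points lower from compound 1 to compound 2 (within the scatter).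

Because the earlier step of a number 7.1 percentage points lower from compound 1 to compound 2 (within the scatter) stayed within the scatter, a comparable small step is expected from compound 3, a number 2.7 percentage points lower from compound 3 to compound 4 (within the scatter). Compound 4 is therefore estimated at 14%, with a likely range from 4% to 28%.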

Compound 4, a percentage reported as inhibition, at one concentration (the size of the read-out at that concentration, not a potency): -7%
For compound 4 the middle estimate is 21 percentage points above the measured one; the measured number lies below the stated range.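

In this assay, putting the group of 4 heavy atoms in place of the group of 3 heavy atoms on the amide-type chain gives a number 23.7 percentage points lower from compound 3 to compound 4 (beyond the scatter). The size of this step does not carry over unchanged from one core to the other: the same change on two cores in this assay, a number 7.1 percentage points lower (within the scatter) from compound 1 to compound 2 and a number 23.7 percentage points lower (beyond the scatter) from compound 3 to compound 4, 16.6 percentage points apart, beyond the scatter of two such steps. This shows that the same change cannot be assumed to have the same size across these two cores, but it does not show which difference between them sets the size, as the two pairs differ in more than one place.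

From the compounds shown here alone, a longer chain on the core of compound 3 remains open, so no chain-length trend can be drawn there. So does an amine in place of the group of 4 heavy atoms.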